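Exchanging the Ring Substituent on a Shared Core

The source may hold more compounds than are shown below. What is called first, only, known or untested is meant among the compounds shown, and "the series" means these compounds.

Compound 1, `C[C@@H](O[C@H]1CN2C(=O)C=C(c3ccc(NS(C)(=O)=O)cc3)CC2[C@@H]1c1ccc(F)cc1)c1cc(C(F)(F)F)cc(C(F)(F)F)c1`, gives 54 nM in an assay on CHO cells for displacement of a labelled ligand from Substance-P receptor (Homo sapiens), in the presence of a further agent that is not named here; on this read-out lower numbers stand for stronger inhibition and higher numbers for weaker inhibition.
Compound 2, `Cc1cc(C2=CC(=O)N3C[C@H](O[C@H](C)c4cc(C(F)(F)F)cc(C(F)(F)F)c4)[C@@H](c4ccc(F)cc4)C3C2)ccn1`, gives 34 nM in this assay.

Going by the values given here, compound 2 has the lower of the two numbers measured so far, but its separation from compound 1 is small: a 1.6-fold lower number from compound 1 to compound 2 (0.20 log units; within the scatter), so the two cannot be ranked against each other. Compound 3, `CCc1noc(C2=CC(=O)N3C[C@H](O[C@H](C)c4cc(C(F)(F)F)cc(C(F)(F)F)c4)[C@@H](c4ccc(F)cc4)C3C2)n1`, is the next variation on the same double-bonded ring carbon: 3-ethyl-1,2,4-oxadiazol-5-yl in place of 2-methylpyridin-4-yl on a double-bonded ring carbon. Among the compounds with values here, the only measured step that touches this position is the one from compound 1 to compound 2, and it stayed within the scatter, which suggests that this carbon tolerates different groups without a large shift. The entering group resembles neither earlier substituent, so the uncertainty is wide. Compound 3 is therefore expected to give about 50 nM in this assay, within roughly 15 nM to 200 nM, an expected step of a 1.5-fold higher number from compound 2 to compound 3 (0.17 log units; within the scatter).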

Compound 3, half-maximal inhibitory concentration: 27 nM
Estimate against measurement, compound 3: 1.9-fold (0.27 log units) above; low and high end bracket the measured number.
By their numbers in this assay, from the lowest: compounds 3, 2 and 1 (each within the scatter of the next).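

In this assay, 3-ethyl-1,2,4-oxadiazol-5-yl can stand in for 2-methylpyridin-4-yl (a 1.3-fold lower number from compound 2 to compound 3 (0.10 log units; within the scatter)), so this double-bonded ring carbon accepts a five-membered aromatic ring with 3 hetero atoms as well as a six-membered aromatic ring with 1 hetero atom. The comparison with the 4-(methanesulfonamido)phenyl group gives the same reading (a 2.0-fold lower number from compound 1 to compound 3 (0.30 log units; within the scatter)), and none of the three groups placed here is separated from another by more than the scatter. Nothing available explains why such different groups give such close numbers.

Going by these compounds, all three groups contain an aromatic ring, so it remains open whether this carbon would also accept a group without one, such as an amine, a carboxylic acid or a longer alkyl chain. On these data alone, it also remains open whether any group at this position can shift the number beyond the scatter.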